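The source may report more compounds than this note shows. Statements on the series, on what has been measured and on what is new or still open speak of the compounds shown alone.

Compound 1, `CCCSc1nc(N/N=C/c2ccc(C)cc2)c2nnn(Cc3ccccc3)c2n1`: in a functional assay on MCF7 cells (Homo sapiens) for antiproliferative activity, read by MTT assay, with a stated time of 72 h (on this read-out lower numbers stand for stronger inhibition and higher numbers for weaker inhibition), compound 1 reaches only the assay limit, > 64000 nM.
Compound 2, `CCCSc1nc(N/N=C/c2ccccc2Cl)c2nnn(Cc3ccccc3)c2n1`: compound 2 gives 13800 nM.
Compound 3, `CCCSc1nc(N/N=C/c2ccc(N(C)C)cc2)c2nnn(Cc3ccccc3)c2n1`: compound 3 gives 12200 nM.

Compound 3 carries the lowest of the two numbers shown, but its nearest neighbour, compound 2, sits within the scatter of it, so the two cannot be told apart. Compound 4, `CCCSc1nc(N/N=C/c2c(O)ccc3ccccc23)c2nnn(Cc3ccccc3)c2n1`, differs from compound 3 only at the group on the carbon with a double bond to nitrogen: 2-hydroxynaphthalen-1-yl in place of 4-(dimethylamino)phenyl on a carbon with a double bond to nitrogen. Within the data shown here, no measured step repeats this change. Among the measured compounds shown here, the steps that bear on it are the other exchanges of that group: an at least 4.6-fold lower number from compound 1 to compound 2 (0.66 log units; beyond the scatter), an at least 5.2-fold lower number from compound 1 to compound 3 (0.71 log units; beyond the scatter) and a 1.1-fold lower number from compound 2 to compound 3 (0.05 log units; within the scatter). Two of these moved the number beyond the scatter, one did not, so the group matters, yet the direction for the 2-hydroxynaphthalen-1-yl group cannot be read from these compounds. The step that is therefore expected is a 1.1-fold lower number from compound 3 to compound 4 (0.04 log units; within the scatter). Compound 4 is estimated at 11000 nM, between 3000 nM and 45000 nM.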

Compound 4, half-maximal inhibitory concentration: 6400 nM
Estimate against measurement, compound 4: 1.7-fold (0.24 log units) above; the measured number falls inside the stated range.
By their numbers in this assay, from the lowest: compounds 4, 3 and 2 (each within the scatter of the next, the first and the last beyond it). At a limit, above all of these: compound 1.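

In this assay, among these compounds, the 2-hydroxynaphthalen-1-yl group gives the first exchange on this carbon with a double bond to nitrogen that separates two compounds with measured numbers beyond the scatter: a 2.2-fold lower number from compound 2 to compound 4 (0.33 log units; beyond the scatter), while a 1.9-fold lower number from compound 3 to compound 4 (0.28 log units; within the scatter) stays within it. Against the 4-methylphenyl group the exchange reaches an at least 10-fold lower number from compound 1 to compound 4 (1.00 log units; beyond the scatter). Compound 1 stands only at a limit, so that step has no upper bound: the limit of > 64000 nM in this assay, at which 1 of the 4 values shown sits.

The hydroxyl and the second aromatic ring enter together, and the compounds shown leave open which of them carries the step; a plain naphthalen-1-yl or a 2-hydroxyphenyl group would separate the two. Also open, as far as these compounds go, is how the number responds to changes elsewhere on the shared core, such as a longer chain in place of the propyl group on sulfur.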